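The source may hold more compounds than are shown below. What is called first, only, known or untested is meant among the compounds shown, and "the series" means these compounds.

Measured compounds:
Compound 1 `Cn1c(-c2ccc(NC(=O)CCl)cc2)nc(-c2ccccc2)c1-c1ccccc1` gives 14.2% in a functional assay on MCF7 cells (Homo sapiens) for cytotoxicity, read by MTT assay, with a stated time of 24 h, tested at 6.4 ug/mL; on this read-out lower numbers stand for a weaker effect and higher numbers for a stronger effect at the one concentration tested.
Compound 2 `Cn1c(-c2ccc(NC(=O)CSc3nc4ccccc4s3)cc2)nc(-c2ccccc2)c1-c1ccccc1` gives 27% in this assay.

Compound 2 stands highest of the two numbers in this assay; its nearest neighbour is compound 1, and the step between them, a number 12.8 percentage points higher from compound 1 to compound 2 (beyond the scatter), lies beyond the scatter. That step exchanged a chloro for a (1,3-benzothiazol-2-yl)sulfanyl on the saturated chain carbon bound to the carbonyl carbon.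

Compound 3 `Cc1nnc(SCC(=O)Nc2ccc(-c3nc(-c4ccccc4)c(-c4ccccc4)n3C)cc2)s1` keeps the sulfanyl link and alters only the heteroaryl on it: 5-methyl-1,3,4-thiadiazol-2-yl in place of 1,3-benzothiazol-2-yl on a sulfur. Going by the values given here, no measured step exchanges one heteroaryl for another on this sulfur, so the single step from compound 1 to compound 2 bears on it only indirectly; it shows that the tail on this carbon can move the read-out by a modest amount. Among the compounds with values here, a smaller group with an additional ring nitrogen enters, and with no closer precedent the expectation for compound 3 is a number near that of compound 2, within the scatter or slightly below it. This means an expected a number 5 percentage points lower from compound 2 to compound 3 (within the scatter). Compound 3 is therefore estimated at 22% in this assay, with a range from 8% to 36%.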

Compound 3, a percentage reported as activity, at one concentration (the size of the read-out at that concentration, not a potency): 67.8%
For compound 3 the middle estimate is 45.8 percentage points below the measured one; measured number above the stated range.
By their numbers in this assay, from the lowest: compound 1; then compound 2; then compound 3.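

The identity of the ring on this sulfur proves to matter far more than the earlier pair could indicate. In this assay, putting 5-methyl-1,3,4-thiadiazol-2-yl in place of 1,3-benzothiazol-2-yl gives a number 40.8 percentage points higher from compound 2 to compound 3 (beyond the scatter), a large step, so two tails joined through the same sulfur and the same saturated chain carbon do not read alike. Set against the chloro compound, the (5-methyl-1,3,4-thiadiazol-2-yl)sulfanyl tail gives a number 53.6 percentage points higher from compound 1 to compound 3 (beyond the scatter), far larger than the modest a number 12.8 percentage points higher from compound 1 to compound 2 (beyond the scatter), which shows that replacing chloro with a heteroaryl sulfanyl group does not by itself fix the size of the change on this carbon. Nothing given here accounts for the difference between the two rings.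

The compounds shown cannot separate the contribution of the methyl group from that of the ring, which a plain 1,3,4-thiadiazol-2-yl on the same sulfur would address. They also leave open whether the sulfur link itself is needed, as a comparison with a piperazine or a morpholine attached directly to the chain carbon in place of the whole sulfanyl tail could show.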